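Moving the double bond in the side chain of compound 3

A few compounds are considered here, and "the series" means these few. Any claim that something is new, unique, unknown or untested is made for them only; others in the source may bear on it.

In a physicochemical assay for acid dissociation, compound 1 `Brc1cccc(Br)c1N(CC1CC1)C1=NCCN1` gives 10.9, compound 2 `CCN(C1=NCCN1)c1c(Br)cccc1Br` gives 11.1 and compound 3 `CC(C)=CCN(C1=NCCN1)c1c(Br)cccc1Br` gives 10.8. Compound 3 therefore stands level with the other two, as all three numbers lie within the scatter of one another.

Compound 4 `C=C(C)CCN(C1=NCCN1)c1c(Br)cccc1Br` is still unmeasured. Its difference from compound 3 is 2-methylprop-2-en-1-yl in place of 2-methylprop-1-en-1-yl on a saturated chain carbon bound to a nitrogen on an aromatic ring. The two have the same atoms, joined differently. Cut one bond further out, the change reads 3-methylbut-2-en-1-yl to 3-methylbut-3-en-1-yl.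

Three measured steps at this same place bear on the change: a number 0.20 log units higher from compound 1 to compound 2 (within the scatter), a number 0.10 log units lower from compound 1 to compound 3 (within the scatter) and a number 0.30 log units lower from compound 2 to compound 3 (within the scatter). Among compounds 1, 2 and 3, exchanging these groups has produced no step beyond the scatter, so none is expected in this assay here. The estimated step is a number 0.10 log units higher from compound 3 to compound 4 (within the scatter), with no direction to be claimed. For compound 4 the expected value is 10.9, with an estimated range of 10.6 to 11.2.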

Compound 4, acid dissociation constant: 10.9
Estimate against measurement, compound 4: no gap at the digits printed; measured number inside the range.
By their numbers in this assay, from the lowest: compounds 3, 1, 4 and 2 (each within the scatter of the next).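

In this assay, shifting the double bond within the side chain gives a number 0.10 log units higher from compound 3 to compound 4 (within the scatter), so a change in how the same atoms are joined behaves here like the earlier exchanges of group. The other two new steps read alike, a number 0.20 log units lower from compound 2 to compound 4 (within the scatter) and no change at the digits printed from compound 1 to compound 4 (within the scatter), which leaves all four compounds within the scatter of one another at this position. No measurement at hand accounts for this flat read-out.

From the compounds shown here alone, all four compounds carry only hydrocarbon groups at this place, so whether an amine, a carboxylic acid or a longer chain would also stay within the scatter in this assay remains open. Going by these compounds, what a change on the shared core would do to this read-out is equally open.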